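The source may report more compounds than this note shows. Statements on the series, on what has been measured and on what is new or still open speak of the compounds shown alone.

Compound 1 (`C[C@@H](NC(=O)Nc1ccc2c(Cl)c(OCCSC(=N)N)oc(=O)c2c1)c1ccccc1`) gives 1.03 h
Compound 2 (`N=C(N)SCCOc1oc(=O)c2cc(NC(=O)CCc3ccccc3)ccc2c1Cl`) gives 0.65 h
Compound 3 (`C[C@H](NC(=O)Nc1ccc2c(Cl)c(OCCSC(=N)N)oc(=O)c2c1)c1ccccc1`) gives 0.933 h

In an ADME assay for pharmacokinetics (on this read-out lower numbers stand for a shorter-lived compound and higher numbers for a longer-lived compound), compound 3 (0.933 h) lies within the scatter of both other compounds, so the three cannot be ranked. The two steps that reach it are small: one shows a 1.1-fold lower number from compound 1 to compound 3 (0.04 log units; within the scatter) and the other shows a 1.4-fold higher number from compound 2 to compound 3 (0.16 log units; within the scatter).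

The next compound to be read is compound 4 (`CC(=O)CCC(=O)Nc1ccc2c(Cl)c(OCCSC(=N)N)oc(=O)c2c1`). The change is 2-acetylethyl in place of (1-phenylethyl)amino on a carbonyl carbon. With the (1-phenylethyl)amino group, the six-membered aromatic ring of carbon only and the defined stereocentre leave, and no ring enters.

The closest evidence comes from the same carbonyl carbon, where swapping (1-phenylethyl)amino for phenethyl gave a 1.6-fold lower number from compound 1 to compound 2 (0.20 log units; within the scatter). This step and the two above all stay within the scatter. However, each of these compounds keeps its aromatic ring, so no measured step covers the loss of that ring, and the expectation is correspondingly loose. No step beyond the scatter is expected in this assay, and no firm direction can be assigned. The estimated step is a 1.2-fold lower number from compound 3 to compound 4 (0.07 log units; within the scatter).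

For compound 4 the expected value is 0.8 h, with an estimated range from 0.4 h to 1.6 h.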

Compound 4, half-life: 0.467 h
Compound 4: middle estimate off by 1.7-fold (0.23 log units), on the high side; the measured number falls inside the stated range.
By their numbers in this assay, from the lowest: compounds 4, 2, 3 and 1 (each within the scatter of the next, the first and the last beyond it).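

In this assay, going by these compounds alone, a change on this carbonyl carbon gives the first step beyond the scatter, though only a modest one (a 2.2-fold lower number from compound 1 to compound 4 (0.34 log units; beyond the scatter)). Within the data shown here, the same group change read from the other stereo form stays within the scatter (a 2.0-fold lower number from compound 3 to compound 4 (0.30 log units; within the scatter)), so the result separates compound 4 from only one of the two compounds carrying (1-phenylethyl)amino. Acetyl in place of phenyl on the saturated chain, with the amide-type nitrogen kept on the carbonyl carbon, also stays within the scatter (a 1.4-fold lower number from compound 2 to compound 4 (0.14 log units; within the scatter)), so losing the aromatic ring has not been shown to matter on its own in this read-out. Nothing in the data at hand accounts for these steps.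

The compounds shown leave open whether the gap from compound 1 would hold up on repeat measurement, given that the other three steps to compound 4 lie within the scatter. They also leave open how a carboxylic acid, a primary amine or a longer saturated chain would read on this carbonyl carbon in place of 2-acetylethyl.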